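The source may report more compounds than this note shows. Statements on the series, on what has been measured and on what is new or still open speak of the compounds shown alone.

Two numbers are in hand so far. Compound 1 `O=C(O)c1cnc2cc(OCCOc3ccccc3)ccc2c1O` is the parent, and in an assay on isolated protein with malate dehydrogenase, mitochondrial (Sus scrofa) as the target (a lower number here means a stronger inhibitor, a higher number a weaker inhibitor), compound 1 gives 60300 nM. Compound 2 `O=C(O)c1cnc2cc(OCCOc3ccc(F)cc3)ccc2c1O` carries fluoro on the phenoxy ring, and in this assay compound 2 gives 18200 nM. Within the data shown here, the single measured step, a 3.3-fold lower number from compound 1 to compound 2 (0.52 log units; beyond the scatter), is fluoro in place of hydrogen on an aromatic carbon. Among the measured compounds shown here, compound 2 therefore stands at the lowest of the two numbers, with compound 1 as its only neighbour.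

Compound 3 `O=C(O)c1cnc2cc(OCCOc3ccc(Br)cc3)ccc2c1O` is the next member. The change from compound 2 is bromo in place of fluoro on an aromatic carbon, para to a large group. For the measured compounds named here, no measured step covers this exchange of one halogen for another. Going by the values given here, the only step that bears on it, a 3.3-fold lower number from compound 1 to compound 2 (0.52 log units; beyond the scatter), concerns the same aromatic carbon but a different substituent; it was modest and beyond the scatter. Going from fluoro to bromo may carry part of that gain further, but no measured pair supports more than a small step. The step expected in this assay is a 1.5-fold lower number from compound 2 to compound 3 (0.18 log units; within the scatter), a modest lowering at most, possibly none beyond the scatter. Compound 3 is estimated at 12000 nM, with a range of 5000 nM to 35000 nM.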

Compound 3, half-maximal inhibitory concentration: 5130 nM
Estimate against measurement, compound 3: 2.3-fold (0.37 log units) above; the range from low to high includes it.
By their numbers in this assay, from the lowest: compound 3; then compound 2; then compound 1.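

In this assay the identity of the halogen on this aromatic carbon, para to a large group, matters and not only its presence: the exchange of fluoro for bromo alone gives a 3.5-fold lower number from compound 2 to compound 3 (0.55 log units; beyond the scatter) and so stands beyond the scatter, as the first step from hydrogen to fluoro did. The gain seen with fluoro was therefore no ceiling, and measured from the parent the bromo compound shows a 12-fold lower number from compound 1 to compound 3 (1.07 log units; beyond the scatter) as a large step where each single halogen step was modest. Across these three compounds the number falls in the order hydrogen, fluoro, bromo, with no compound going against that order, though three points on one carbon support nothing wider than this short sequence.

From the compounds shown here alone, whether chloro or iodo on the same carbon falls into this order, whether a methyl or methoxy group there would follow it, and whether a longer chain in the linking ether keeps the gain from bromo all remain open. Nothing in hand bears on why bromo gives the lower number.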